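The source may report more compounds than this note shows. Statements on the series, on what has been measured and on what is new or still open speak of the compounds shown alone.

Measured half-lives so far:
- compound 1 `Cc1cc(C(F)(F)F)ccc1-c1cc2cnn([C@@H](CC(C)C)c3ccc(C(=O)NCCC(=O)O)cc3)c2cc1C`: 7.2 h
- compound 2 `Cc1cc(C(F)(F)F)ccc1-c1cc2cn([C@@H](CC(C)C)c3ccc(C(=O)NCCC(=O)O)cc3)nc2cc1C`: 4.5 h

In an ADME assay on the whole organism (Mus musculus, strain C57) for metabolic stability, at a dose of 5 mg/kg by the intravenous route (a higher number here means that the compound lasts longer, a lower number that the compound disappears faster), compound 1 gives 7.2 h and compound 2 gives 4.5 h as its value. These two numbers lie within the scatter of each other, so compound 1 cannot be separated from compound 2 on these data.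

The next compound to be measured is compound 3 `Cc1cc2c(cnn2[C@@H](CC(C)C)c2ccc(C(=O)NCCC(=O)O)cc2)cc1-c1ccc(C(F)(F)F)cc1Cl`, which departs from compound 1 in one place: chloro in place of methyl on an aromatic carbon. Put another way, the 2-methyl-4-(trifluoromethyl)phenyl group of compound 1 becomes a 2-chloro-4-(trifluoromethyl)phenyl group in compound 3.

Within the data shown here, no measured pair shows this change or any other single-place change, so the data give no direction for it. With compound 1 at 7.2 h as the only close reference, no step beyond the scatter is expected in this assay. The expected change is a 1.0-fold lower number from compound 1 to compound 3 (0.01 log units; within the scatter) as an estimate. For compound 3 the estimated half-life is 7 h, with an expected range from 3.5 h to 14 h as its limits of estimate.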

Compound 3, half-life: 7.8 h
Estimate against measurement, compound 3: 1.1-fold (0.05 log units) below; the measured number falls inside the stated range.
By their numbers in this assay, from the lowest: compounds 2, 1 and 3 (each within the scatter of the next).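

In this assay, among these compounds, the change from 2-methyl-4-(trifluoromethyl)phenyl to 2-chloro-4-(trifluoromethyl)phenyl provides the first single-place step, a 1.1-fold higher number from compound 1 to compound 3 (0.03 log units; within the scatter), and so gives this aromatic carbon, ortho to a large group, its first direct reading. With compound 1 at 7.2 h and compound 3 at 7.8 h, chloro and methyl cannot be separated at this position by half-life, so this one exchange leaves the read-out within the scatter. No available measurement explains this result or links it to a property of either group.

Still open is whether this position stays equally insensitive with a hydrogen, a fluoro, a methoxy or a nitrile on this carbon, since methyl and chloro are the only two groups shown there. Also open, from the compounds shown here alone, is whether the same exchange reads alike on compound 2, and whether a change elsewhere, such as a nitrile in place of the trifluoromethyl group, would give a step beyond the scatter in this assay.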